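This account rests on a few compounds, and the source may have more. Where it says the series, first, only, none or still open, it means among the compounds named here.

Measured in a functional assay on KB cells (Homo sapiens) for cytotoxicity, read by resazurin assay, with a stated time of 3 days; on this read-out lower numbers stand for stronger inhibition and higher numbers for weaker inhibition:
compound 1 `CC(C)(CNC(=O)c1ccccc1)CC1=C(O)C(=O)c2ccccc2C1=O` gives 15200 nM
compound 2 `COC1=C(CC(C)(C)CNC(=O)c2ccccc2)C(=O)c2ccccc2C1=O` gives 117000 nM
compound 3 `COC1=C(CC(C)(C)CNC(=O)c2ccc3ccccc3c2OC)C(=O)c2ccccc2C1=O` gives 64100 nM

Compound 4 `COc1c(C(=O)NCC(C)(C)CC2=C(O)C(=O)c3ccccc3C2=O)ccc2ccccc12` is not yet measured. Compound 3 and compound 4 differ as follows: hydrogen in place of methyl on an oxygen on an unsaturated carbon. The same change separates compound 2 from compound 1: hydrogen in place of methyl on an oxygen on an unsaturated carbon. Within the measured set that change made a 7.7-fold lower number from compound 2 to compound 1 (0.89 log units; beyond the scatter). The difference between the core of compound 2 and that of compound 3 is not broken down here; compound 3 and compound 2 lie within the scatter of each other, and each lies beyond the scatter from compound 1. Among the compounds with values here, for compound 4 a step of the same kind is expected, a 7.1-fold lower number from compound 3 to compound 4 (0.85 log units; beyond the scatter), resting on the single earlier instance and on the place of the change being the same in both pairs. The estimate for compound 4 in this assay is 9000 nM, with a range from 3000 nM to 30000 nM.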

Compound 4, half-maximal inhibitory concentration: 66900 nM
Compound 4: middle estimate off by 7.4-fold (0.87 log units), on the low side, outside the stated range (above it).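

In this assay, the change from methoxy to hydroxy gives a 1.0-fold higher number from compound 3 to compound 4 (0.02 log units; within the scatter). Set beside the earlier step, the same change does not carry over from one core to the other: the same change on two cores in this assay, a 7.7-fold lower number (0.89 log units; beyond the scatter) from compound 2 to compound 1 and a 1.0-fold higher number (0.02 log units; within the scatter) from compound 3 to compound 4, 8.0-fold (0.90 log units) apart, beyond the scatter of two such steps. The effect of this change therefore depends on the core in these two pairs, but two pairs do not show which part of the difference between the cores is responsible, or what the change would do on a third core.

The compounds shown leave open what an amine or a carboxylic acid in place of the hydroxy would give on either core. They also leave open whether a longer chain would alter the result.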